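Aryl phosphate fluoropyrimidine nucleosides: quinolinyl for pyridinyl

The source may report more compounds than this note shows. Statements on the series, on what has been measured and on what is new or still open speak of the compounds shown alone.

Measured so far in a functional assay on T98G cells (Homo sapiens) for cytotoxicity, read by MTT assay, with a stated time of 48 h; a higher number here means a weaker inhibitor, a lower number a stronger inhibitor:

compound 1 `O=C(O[C@H]1C[C@H](n2cc(F)c(=O)[nH]c2=O)O[C@@H]1COP(=O)(O)Oc1cccnc1)c1ccccc1` gives 1300 nM
compound 2 `O=C(O[C@H]1C[C@H](n2cc(F)c(=O)[nH]c2=O)O[C@@H]1COP(=O)(O)Oc1ccc2ncccc2c1)c1ccccc1` gives 1300 nM
compound 3 `O=c1[nH]c(=O)n([C@H]2C[C@H](O)[C@@H](COP(=O)(O)Oc3cccnc3)O2)cc1F` gives 1200 nM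

The change quinolin-6-yl in place of pyridin-3-yl on an oxygen has been made once among the measured compounds, and its step in this assay is no change at the digits printed from compound 1 to compound 2 (within the scatter). Compound 4 `O=c1[nH]c(=O)n([C@H]2C[C@H](O)[C@@H](COP(=O)(O)Oc3ccc4ncccc4c3)O2)cc1F` carries the same change, (quinolin-6-yl in place of pyridin-3-yl on an oxygen), on the core of compound 3. The two cores differ by hydrogen in place of benzoyl on an oxygen on a saturated carbon, a change whose own step is a 1.1-fold lower number from compound 1 to compound 3 (0.03 log units; within the scatter). The place of the change is described in the same words for both pairs, so this is the same change on a core that differs only in that way. The step from compound 3 to compound 4 is therefore expected to be no change at the digits printed from compound 3 to compound 4 (within the scatter), resting on the step from compound 1 to compound 2 in this assay, no change at the digits printed from compound 1 to compound 2 (within the scatter). Compound 4 is estimated at 1200 nM (range 600 nM to 2400 nM).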

Compound 4, half-maximal inhibitory concentration: 1900 nM
Compound 4: the middle estimate sits 1.6-fold (0.20 log units) below what was measured, within the range that was stated.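

In this assay, quinolin-6-yl in place of pyridin-3-yl on an oxygen gives a 1.6-fold higher number from compound 3 to compound 4 (0.20 log units; within the scatter), and this agrees with the same change on the other core: the same change on two cores in this assay, no change at the digits printed (within the scatter) from compound 1 to compound 2 and a 1.6-fold higher number (0.20 log units; within the scatter) from compound 3 to compound 4, 1.6-fold (0.20 log units) apart, within the scatter of two such steps

Hydrogen in place of benzoyl on an oxygen on a saturated carbon gives a 1.5-fold higher number from compound 2 to compound 4 (0.16 log units; within the scatter), which also agrees with its earlier step: the same change on two cores in this assay, a 1.1-fold lower number (0.03 log units; within the scatter) from compound 1 to compound 3 and a 1.5-fold higher number (0.16 log units; within the scatter) from compound 2 to compound 4, 1.6-fold (0.20 log units) apart, within the scatter of two such steps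

Both changes therefore carry between these two cores without a difference that can be told from the scatter, but every step is itself within the scatter, so this does not show that a change with a real effect would carry in the same way.

The compounds shown leave open how an acetyl group in place of benzoyl would behave. The same applies to a carboxylic acid or an amine on the quinolin-6-yl group.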